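The compounds below may be only part of what the source reports. "The series", "measured", "known", "first", "only" and "open" are said of these compounds alone.

For the measured compounds named here, compound 3 `Cc1ccc(-n2[nH]c(C)c(/N=N/c3c(O)cc(S(=O)(=O)O)c4ccccc34)c2=O)cc1C` gives the highest of the two numbers so far in an assay on BaF3 cells with thrombopoietin receptor (Homo sapiens) as the target, read by a luciferase reporter (a higher number here means a larger maximal response, a lower number a smaller maximal response), where compound 3 reaches 100%. Compound 2 `Cc1[nH]n(-c2ccc(I)cc2)c(=O)c1/N=N/c1c(O)cc(S(=O)(=O)O)c2ccccc12` reaches 81% in this assay. Compound 1 `Cc1[nH]n(C)c(=O)c1/N=N/c1c(O)cc(S(=O)(=O)O)c2ccccc12` sits at a limit of this assay, < 5%, which is a limit and not a number (the limit of < 5% in this assay, at which 1 of the 3 values shown sits).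

The steps measured all concern the group on the aromatic nitrogen: a number at least 76 percentage points higher from compound 1 to compound 2 (beyond the scatter); a number at least 95 percentage points higher from compound 1 to compound 3 (beyond the scatter); and between the two aryl groups, a number 19 percentage points higher from compound 2 to compound 3 (beyond the scatter).

Compound 4 `Cc1[nH]n(-c2ccc(C(=O)O)cc2)c(=O)c1/N=N/c1c(O)cc(S(=O)(=O)O)c2ccccc12` differs from compound 3 as follows. 4-carboxyphenyl in place of 3,4-dimethylphenyl on an aromatic nitrogen

The step from compound 3 to compound 4 keeps an aryl group on the aromatic nitrogen, the change that carried both large gains over compound 1. Going by the values given here, the only comparison between two aryl groups, the step from compound 2 to compound 3, was modest. A modest step downward in this assay is therefore expected, on the order of a number 30 percentage points lower from compound 3 to compound 4 (beyond the scatter), with no basis to expect a return toward the limit seen for compound 1. Compound 4 is estimated at 70%, in a range from 35% to 100%.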

Compound 4, largest response reached (reported as efficacy), in percent of the reference or control that the assay uses: < 5%
Compound 4 gave a limit, no number; the forecaster's own chance of this, stated with the estimate: 10%; middle value at least 65 percentage points from the limit.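

An aryl group on the aromatic nitrogen is not sufficient for a response in this assay: what the aryl group carries also matters, with a number at least 95 percentage points lower from compound 3 to compound 4 (beyond the scatter) and a number at least 76 percentage points lower from compound 2 to compound 4 (beyond the scatter). Compound 4 therefore goes against the reading from compound 2 and compound 3 that an aryl group at this position is enough. Compound 4 gives < 5%, which is a limit and not a number, and the step from compound 1 to compound 4 cannot be read, so the series now holds two such values: the limit of < 5% in this assay, at which 2 of the 4 values shown sit.

On these data alone, it remains open whether the loss goes with the carboxy group itself or would also follow from other groups on the phenyl ring. A methyl ester, a primary amide or an amine in place of the carboxy group would separate these readings.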